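A few compounds are considered here, and "the series" means these few. Any claim that something is new, unique, unknown or untested is made for them only; others in the source may bear on it.

Working notes on the (2-hydroxyethoxy)methyl series

All three measured compounds carry a (2-hydroxyethoxy)methyl group on a ring nitrogen of their respective cores. Compound 1 `Cc1cn(COCCO)c(=O)[nH]c1=O` gives in a functional assay (Oryctolagus cuniculus) for inhibition (a higher number here means a weaker inhibitor, a lower number a stronger inhibitor), a value of > 400 ug/mL, which is a limit of the assay and not a number. Compound 2 `O=c1cc(O)ccn1COCCO` likewise gives in this assay a value of > 400 ug/mL, again a limit. Compound 3 `Nc1nc2c(nc(Br)n2COCCO)c(=O)[nH]1` gives in this assay a value of 340 ug/mL. Within the data shown here, that is the only actual number in the set; the other two values sit at the limit of > 400 ug/mL in this assay, at which 2 of the 3 values shown sit, so compound 3 stands as the single compound with a measurable, if weak, read-out.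

Compound 4 `CNc1nc2c(=O)[nH]c(N)nc2n1COCCO` has not yet been measured in this assay. It differs from compound 3 in one place: methylamino in place of bromo on an aromatic carbon. Among the measured compounds shown here, no pair of measured compounds differs in one place, so there is no measured step to rest on, and the only anchor is the weak number of compound 3, 340 ug/mL in this assay.

The step expected in this assay is a 1.0-fold higher number from compound 3 to compound 4 (0.01 log units; within the scatter), that is, none beyond the scatter, with a real chance that the read-out ends at a limit. For compound 4 the estimate in this assay is 350 ug/mL, with a range from 120 ug/mL to 1000 ug/mL.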

Compound 4, concentration for 50% inhibition: > 400 ug/mL
Compound 4: a limit, no number; the forecaster's own chance of this, stated with the estimate: 50%; at least 1.1-fold (0.05 log units) between middle value and limit.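

Among these compounds, the exchange of bromo for methylamino on an aromatic carbon gives the first step that can be read at all, in this assay: an at least 1.1-fold higher number from compound 3 to compound 4 (0.07 log units; that floor lies within the scatter). Only a floor is known for this step and the true size stays undetermined, but at this position, between two ring nitrogen atoms and next to the ring atom that bears the (2-hydroxyethoxy)methyl group, methylamino brings no gain in inhibition that can be read. Compound 4 gives a limit and not a number, and so it joins compound 1 and compound 2 at the end of the read-out: the limit of > 400 ug/mL in this assay, at which 3 of the 4 values shown sit.

The compounds shown hold only bromo and methylamino at this carbon, so it stays open whether the measurable read-out of compound 3 belongs to bromo in particular or would also appear with chloro, iodo or a plain methyl group. Going by these compounds, it also stays open how a plain amine or a longer chain such as butylamino would read there, and with a number this far up the scale, any real difference on the shared core could only be seen with a compound that reads well clear of the limit.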